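Working notes: from benzamido to benzylsulfanyl

A few compounds are considered here, and "the series" means these few. Any claim that something is new, unique, unknown or untested is made for them only; others in the source may bear on it.

Values measured so far in a functional assay on HepG2 cells (Homo sapiens) for antiproliferative activity, read by MTT assay, with a stated time of 48 h (a lower number here means a stronger inhibitor, a higher number a weaker inhibitor), are these
- compound 1 `Cc1ccc(-c2nc(NO)c3cc(Cl)ccc3n2)cc1` (23.1 ug/mL)
- compound 2 `Cc1ccc(-c2nc(NC(=O)c3ccccc3)c3cc(Cl)ccc3n2)cc1` (17.5 ug/mL)

Compound 2 and compound 1 stand within the scatter of each other, so compound 2 holds no separate place in this pair. Going by the values given here, the only measured step is a 1.3-fold lower number from compound 1 to compound 2 (0.12 log units; within the scatter) with benzoyl in place of hydroxy on a nitrogen on an aromatic ring.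

Compound 3 `Cc1ccc(-c2nc(SCc3ccccc3)c3cc(Cl)ccc3n2)cc1` has benzylsulfanyl in place of benzamido on an aromatic carbon. Among the compounds with values here, the measured step changes only the group on the nitrogen, and no measured compound carries benzylsulfanyl, so that step bears on this change only loosely. Within the data shown here, with one small step as the sole guide, no step beyond the scatter is expected in this assay in either direction, and the range has to stay wide. The estimated step is a 1.0-fold higher number from compound 2 to compound 3 (0.01 log units; within the scatter) on this reasoning. For compound 3 the expected value is 18 ug/mL with an estimated range from 8 ug/mL to 40 ug/mL in this assay.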

Compound 3, half-maximal inhibitory concentration: 18.4 ug/mL
Compound 3: the middle estimate sits 1.0-fold (0.01 log units) below what was measured; measured number inside the range.
By their numbers in this assay, from the lowest: compounds 2, 3 and 1 (each within the scatter of the next).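

In this assay, going by these compounds alone, the step of a 1.1-fold higher number from compound 2 to compound 3 (0.02 log units; within the scatter) is the first comparison at this position, on an aromatic carbon next to the ring nitrogen, in which the atom attached to the ring is not nitrogen. Exchanging benzamido for benzylsulfanyl removes the carbonyl and the amide hydrogen and keeps the six-membered aromatic ring of the substituent, yet the two compounds stay within the scatter of each other. The step of a 1.3-fold lower number from compound 1 to compound 3 (0.10 log units; within the scatter) gives the same reading against the much smaller hydroxyamino group, so hydroxyamino, benzamido and benzylsulfanyl are not separated at this position in this assay, and no independent measurement is available to interpret this flat result.

Still open, from the compounds shown here alone, is whether this flat reading extends to other groups at this carbon, such as a primary amine, a carboxylic acid or a longer alkyl chain. Going by these compounds, the 4-methylphenyl group is also common to all three compounds, so its contribution, and whether a change there would shift the values more than changes at this position do, remains unknown.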